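Shortening the amide substituent: expected cytotoxicity of compound 3

This account rests on a few compounds, and the source may have more. Where it says the series, first, only, none or still open, it means among the compounds named here.

In an ADME assay on MT2 cells (Homo sapiens) for cytotoxicity (on this read-out higher numbers stand for lower toxicity in this test and lower numbers for higher toxicity in this test), compound 2 `Cc1nc2cc(C(=O)NCc3ccc(F)cc3-n3cncn3)nn2c(-c2cc(F)c3c(c2C)CCCO3)c1[C@H](OC(C)(C)C)C(=O)O` gives > 40000 nM, a value that is a limit of the assay rather than a measured number. Compound 1 `Cc1nc2cc(C(=O)NCc3ccc(F)cc3S(C)(=O)=O)nn2c(-c2cc(F)c3c(c2C)CCCO3)c1[C@H](OC(C)(C)C)C(=O)O` gives > 40000 nM in this assay, again a limit. The step that the two limits leave unreadable from compound 1 to compound 2 therefore cannot be read. Compound 3 `CCCNC(=O)c1cc2nc(C)c([C@H](OC(C)(C)C)C(=O)O)c(-c3cc(F)c4c(c3C)CCCO4)n2n1` differs from compound 2 by ethyl in place of 4-fluoro-2-(1H-1,2,4-triazol-1-yl)phenyl on a saturated chain carbon bound to an amide-type nitrogen. Among the compounds with values here, no measured step matches this change, and the one known step is unreadable; the only evidence is the limit of > 40000 nM in this assay, at which 2 of the 2 values shown sit. Compound 3 is expected to stay at that limit, an expected step of a number no higher from compound 2 to compound 3 (the limit leaves the size open). The estimate for compound 3 is 40000 nM, between 20000 nM and 80000 nM.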

Compound 3, half-maximal cytotoxic concentration: > 40000 nM
Compound 3 was reported as a limit (the forecaster's own chance of this, stated with the estimate: 80%); the middle value sits exactly at the limit.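

The steps among compound 1, compound 2 and compound 3 cannot be read, as each result in this assay is only a limit: the limit of > 40000 nM in this assay, at which 3 of the 3 values shown sit.

The compounds shown leave open the concentration at which each becomes cytotoxic, and whether their amide substituents differ in this respect at all.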